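Replacing the substituted phenyl group of compound 3

This account rests on a few compounds, and the source may have more. Where it says the series, first, only, none or still open, it means among the compounds named here.

Measured so far:
- Compound 1 `O=C(CSc1nnc(-c2ccncc2)o1)N/N=C/c1ccc(Cl)cc1`: 15300 nM
- Compound 2 `O=C(CSc1nnc(-c2ccncc2)o1)N/N=C/c1ccc([N+](=O)[O-])cc1`: 31800 nM
- Compound 3 `O=C(CSc1nnc(-c2ccncc2)o1)N/N=C/c1cc(Cl)cc(Cl)c1O`: 5920 nM

These values come from a functional assay on MCF7 cells (Homo sapiens) for cytotoxicity, read by MTT assay, with a stated time of 48 h; on this read-out lower numbers stand for stronger inhibition and higher numbers for weaker inhibition. Compound 3 has the lowest number of the three, and both steps leading to it lie beyond the scatter: a 2.6-fold lower number from compound 1 to compound 3 (0.41 log units; beyond the scatter) and a 5.4-fold lower number from compound 2 to compound 3 (0.73 log units; beyond the scatter).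

The next compound to be tested is compound 4 `O=C(CSc1nnc(-c2ccncc2)o1)N/N=C/c1ccc(Cl)cc1Cl`. It keeps the shared core, and the change sits on a carbon with a double bond to nitrogen: 2,4-dichlorophenyl in place of 3,5-dichloro-2-hydroxyphenyl on a carbon with a double bond to nitrogen. In words, 2,4-dichlorophenyl takes the place of 3,5-dichloro-2-hydroxyphenyl.

The closest guide is the modest step of a 2.6-fold lower number from compound 1 to compound 3 (0.41 log units; beyond the scatter), as compound 1 also has no hydroxy group on its phenyl ring. The step of a 2.1-fold higher number from compound 1 to compound 2 (0.32 log units; beyond the scatter) is also modest, so all three measured changes to this group stay small. Within the data shown here, no measured compound separates the hydroxy group from the number and placing of the chlorines.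

A modest rise in this assay is therefore expected, meaning somewhat weaker inhibition. The estimated change is a 1.7-fold higher number from compound 3 to compound 4 (0.23 log units; within the scatter). The expected value for compound 4 is 10000 nM, within an estimated range of 4500 nM to 22000 nM.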

Compound 4, half-maximal inhibitory concentration: 27900 nM
Estimate against measurement, compound 4: 2.8-fold (0.45 log units) below, outside the stated range (above it).
By their numbers in this assay, from the lowest: compound 3; then compounds 1, 4 and 2 (each within the scatter of the next, the first and the last beyond it).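

In this assay, 2,4-dichlorophenyl in place of 3,5-dichloro-2-hydroxyphenyl gives a 4.7-fold higher number from compound 3 to compound 4 (0.67 log units; beyond the scatter), so a dichlorophenyl ring alone does not preserve the low number of compound 3, the only compound shown that carries a hydroxy group on this ring. Compound 4 also fails to separate from its two closest comparators: chloro in place of hydrogen on an aromatic carbon gives a 1.8-fold higher number from compound 1 to compound 4 (0.26 log units; within the scatter), and 2,4-dichlorophenyl in place of 4-nitrophenyl gives a 1.1-fold lower number from compound 2 to compound 4 (0.06 log units; within the scatter), both within the usual scatter. No measurement is available to explain why 3,5-dichloro-2-hydroxyphenyl stands apart from the other groups at this position.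

The change from compound 3 to compound 4 removes the hydroxy group and moves the chlorines at the same time, so the compounds shown cannot say how much of the step belongs to either change. As far as these compounds go, it also remains open whether a methoxy group or an amine in place of the hydroxy group, on the same dichlorophenyl ring, would keep the number near that of compound 3 or move it toward those of the other three compounds.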